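Vinyl sulfone series: halogen swap on the phenyl ring

The source may report more compounds than this note shows. Statements on the series, on what has been measured and on what is new or still open speak of the compounds shown alone.

Compound 3 `O=S(=O)(/C=C\c1ccc(Cl)nc1)c1cccc(F)c1` sits at the low end of the three numbers in an assay on U2OS cells for activation of nuclear factor erythroid 2-related factor 2 (Homo sapiens), read by beta-arrestin recruitment, with a stated time of 6 h (a lower number here means that less compound is needed, a higher number that more compound is needed for the effect), where compound 3 gives 965 nM. Compound 1 `O=S(=O)(/C=C/c1cccc(Cl)n1)c1cccc(Cl)c1` gives 1070 nM and lies within the scatter of compound 3. Within the data shown here, compound 2 `O=S(=O)(/C=C\c1cccnc1)c1cccc(F)c1` gives 4820 nM, the furthest of the three, and the one measured step, a 5.0-fold lower number from compound 2 to compound 3 (0.70 log units; beyond the scatter), comes from chloro in place of hydrogen on the pyridine, not from the phenyl.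

Compound 4 `O=S(=O)(/C=C\c1ccc(Cl)nc1)c1cccc(Cl)c1` differs from compound 3 only on the phenyl ring: chloro in place of fluoro on an aromatic carbon. Among the measured compounds shown here, no measured step covers this change. The nearest evidence is compound 1, which carries chloro on its phenyl and gives 1070 nM, within the scatter of compound 3; compound 1 also differs from compound 3 elsewhere, so the comparison is indirect.

On this basis no step beyond the scatter is expected, and the step from compound 3 to compound 4 is estimated at a 1.1-fold lower number from compound 3 to compound 4 (0.03 log units; within the scatter). Compound 4 is expected to give about 900 nM, with a range of 400 nM to 2000 nM.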

Compound 4, half-maximal effective concentration: 3390 nM
For compound 4 the middle estimate is 3.8-fold (0.58 log units) below the measured one, and the stated range ends below it.
By their numbers in this assay, from the lowest: compounds 3 and 1 (each within the scatter of the next); then compounds 4 and 2 (each within the scatter of the next).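

In this assay, the halogen on the six-membered aromatic ring of carbon only is not interchangeable: chloro in place of fluoro gives a 3.5-fold higher number from compound 3 to compound 4 (0.55 log units; beyond the scatter). Among these compounds, the earlier measured step concerned only chloro in place of hydrogen on the other ring, so this is the first measured sign that this position responds to a change of a single halogen atom, and here the entering chloro goes with a higher number rather than a lower one. No measured property bears on this step, and its origin remains unexplained.

Going by these compounds, only fluoro and chloro are compared at this position, so it remains open how hydrogen, a methoxy group, an amine or a carboxylic acid would read there. On these data alone, whether the same swap gives a similar step on the core of compound 1 also remains open.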